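Sulfation of a glycolipid inhibitor: a step foreseen

A few compounds are considered here, and "the series" means these few. Any claim that something is new, unique, unknown or untested is made for them only; others in the source may bear on it.

Compound 1 `CCCCCCCC/C=C\CCCCCCCC(=O)N[C@H]1[C@@H](OCCCCCCCC)O[C@H](CO)[C@@H](O)[C@@H]1O` was tested in a functional assay on C6 cells (Rattus norvegicus), read by thymidine incorporation (a lower number here means a stronger inhibitor, a higher number a weaker inhibitor), where compound 1 gives 12 uM. Two further compounds share a core that differs from the core of compound 1; that difference between the two cores is not broken down here. In this assay compound 3 `CCCCCCCCCCCCCCCCO[C@H]1O[C@H](COCC(CO)(CO)CO)[C@@H](O)[C@H](O)[C@H]1NC(=O)CCCC` gives 18.3 uM, and compound 2 `CCCCCCCCCCCCCCCCO[C@H]1O[C@H](COCC(CO)(CO)COS(=O)(=O)O)[C@@H](O)[C@H](O)[C@H]1NC(=O)CCCC` gives 11 uM. Compound 2 arises from compound 3 by a single change, (sulfo in place of hydrogen on an oxygen on a saturated carbon), and this change made a step of a 1.7-fold lower number from compound 3 to compound 2 (0.22 log units; within the scatter). The numbers for compound 1 and compound 2 lie within the scatter of each other, as do those for compound 1 and compound 3.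

Compound 4 `CCCCCCCC/C=C\CCCCCCCC(=O)N[C@H]1[C@@H](OCCCCCCCC)O[C@H](CO)[C@@H](O)[C@@H]1OS(=O)(=O)O` has not yet been measured. It is derived from compound 1 by sulfo in place of hydrogen on an oxygen on a saturated carbon. Among the four compounds this change occurs twice. It is the same kind of change as that from compound 3 to compound 2, but not the same: in compound 3 the oxygen sits on a saturated carbon whose other neighbour is a saturated chain carbon, whereas in compound 1 the other neighbour is a saturated ring carbon. Resting on the one measured instance of this change, the step from compound 1 to compound 4 in this assay is expected to be small, a 1.3-fold lower number from compound 1 to compound 4 (0.12 log units; within the scatter). Compound 4 is therefore estimated to give about 9 uM, with a likely range from 3.5 uM to 25 uM.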

Compound 4, concentration for 50% inhibition: 5.4 uM
Beside the measured number, compound 4's estimate is 1.7-fold (0.22 log units) above it; low and high end bracket the measured number.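

In this assay, hydroxy to sulfooxy on the core of compound 1 made a modest step, a 2.2-fold lower number from compound 1 to compound 4 (0.35 log units; beyond the scatter), and this step lies beyond the scatter. Set beside the earlier case, the size of the step cannot be told apart between the two cores, so on this evidence it carries over from one core to the other: the same change on two cores in this assay, a 1.7-fold lower number (0.22 log units; within the scatter) from compound 3 to compound 2 and a 2.2-fold lower number (0.35 log units; beyond the scatter) from compound 1 to compound 4, 1.3-fold (0.13 log units) apart, within the scatter of two such steps This does not show that the change gives a step of fixed size across the series, since only two cores are represented, the oxygen sits on a saturated chain carbon in one and on a saturated ring carbon in the other, and only a 1.7-fold lower number from compound 3 to compound 2 (0.22 log units; within the scatter) stands as the comparison, a step that on its own stays within the scatter.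

The compounds shown leave open whether a phosphate or a carboxylic acid in place of the sulfo group would give a step of similar size. They also leave open whether sulfo on another hydroxy group of compound 1, or a longer chain on the oxygen of the core of compound 4, would change the number in this assay.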